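Trimming the Amide Substituent: Compound 2 to Compound 3

The source may report more compounds than this note shows. Statements on the series, on what has been measured and on what is new or still open speak of the compounds shown alone.

In a functional assay on HT-29 cells (Homo sapiens) for inhibition, read by MTT assay, with a stated time of 120 h (on this read-out higher numbers stand for weaker inhibition and lower numbers for stronger inhibition), the measured compounds are:
compound 1 `O=C(/C=C/c1ccc(NC(=O)Nc2ccc(Cl)c(C(F)(F)F)c2)cc1)NC1CCC1`: 4430 nM
compound 2 `CC(NC(=O)/C=C/c1ccc(NC(=O)Nc2ccc(Cl)c(C(F)(F)F)c2)cc1)c1ccccc1`: 1060 nM

Compound 2 holds the lowest of the two numbers; its nearest neighbour is compound 1, separated by a 4.2-fold lower number from compound 1 to compound 2 (0.62 log units; beyond the scatter). Compound 3 `CNC(=O)/C=C/c1ccc(NC(=O)Nc2ccc(Cl)c(C(F)(F)F)c2)cc1` differs from compound 2 by methyl in place of 1-phenylethyl on an amide-type nitrogen. For the measured compounds named here, the only measured step touching this amide-type nitrogen is a 4.2-fold lower number from compound 1 to compound 2 (0.62 log units; beyond the scatter), where the larger group gave the lower number; the present change goes the other way, to a smaller group than either, so a higher number is expected, likely beyond the scatter. Compound 3 is estimated at 7000 nM (range 2500 nM to 25000 nM), which is an expected step of a 6.6-fold higher number from compound 2 to compound 3 (0.82 log units; beyond the scatter).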

Compound 3, half-maximal inhibitory concentration: 11700 nM
Compound 3: middle estimate off by 1.7-fold (0.22 log units), on the low side; measured number inside the range.
By their numbers in this assay, from the lowest: compound 2; then compound 1; then compound 3.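

Cutting the group on the amide-type nitrogen back to methyl in this assay gives a much larger shift than the earlier step showed (an 11-fold higher number from compound 2 to compound 3 (1.04 log units; beyond the scatter)), and methyl also falls short of cyclobutyl (a 2.6-fold higher number from compound 1 to compound 3 (0.42 log units; beyond the scatter)). The three groups now form one order, with 1-phenylethyl lowest, cyclobutyl in the middle and methyl highest, each step beyond the scatter. No available evidence bears on why.

On these data alone, whether 1-phenylethyl owes its place to its aromatic ring or to its greater number of heavy atoms stays open. How a benzyl group, a cyclohexyl group or a chain ending in an amine would rank here is also unknown.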